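This account rests on a few compounds, and the source may have more. Where it says the series, first, only, none or still open, it means among the compounds named here.

Measured compounds:
compound 1, `COc1cc(/C=C/C(=O)C2=C(/C=C/c3ccc(O)c(OC)c3)NC(=O)NC2c2ccc(O)cc2)ccc1O`, 80.1% in a functional assay, with a stated time of 20 min, tested at 20 uM; a higher number here means a stronger effect of the compound at the concentration tested, a lower number a weaker effect
compound 2, `COc1cc(/C=C/C(=O)C2=C(/C=C/c3ccc(O)c(OC)c3)NC(=O)NC2c2ccccc2Cl)ccc1O`, 38.7%
compound 3, `COc1cc(/C=C/C(=O)C2=C(/C=C/c3ccc(O)c(OC)c3)NC(=S)NC2c2ccccc2)ccc1O`, 36.6%

Among these three values, compound 3 is nearest to compound 2, the two lying within the scatter of each other, and it stands well below compound 1, a gap beyond the scatter. For the measured compounds named here, the only single-place step among the measured compounds is a number 41.4 percentage points lower from compound 1 to compound 2 (beyond the scatter), a large drop for an exchange on the saturated ring carbon.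

Compound 4 is `COc1cc(/C=C/C(=O)C2=C(/C=C/c3ccc(O)c(OC)c3)NC(=S)NC2c2ccc(C)cc2)ccc1O`. It differs from compound 3 in one place: methyl in place of hydrogen on an aromatic carbon. Cut one bond further out, the change reads phenyl to 4-methylphenyl.

Going by the values given here, no measured step bears directly on this change. Among the compounds with values here, the one step on record concerns the same saturated ring carbon but a different exchange, the whole aryl group rather than a single substituent on it, and compound 3 already carries the thiourea that sets it apart from both compound 1 and compound 2. Within the data shown here, a methyl entering para to a large group on this ring has no precedent here, so the expected step of a number 0.4 percentage points higher from compound 3 to compound 4 (within the scatter) is none beyond the scatter. Compound 4 is therefore estimated at 37%, with a range from 22% to 52%.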

Compound 4, a percentage reported as activity, at one concentration (the size of the read-out at that concentration, not a potency): 30%
Estimate against measurement, compound 4: 7 percentage points above, within the range that was stated.
By their numbers in this assay, from the lowest: compounds 4, 3 and 2 (each within the scatter of the next); then compound 1.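

In this assay, methyl in place of hydrogen on an aromatic carbon, para to a large group, gives a number 6.6 percentage points lower from compound 3 to compound 4 (within the scatter), so this exchange of phenyl for 4-methylphenyl does not move the read-out past the usual scatter. For the compounds shown here, it is the first step on record that alters a single substituent on this aryl ring while the rest of the compound stays the same, and it stands apart in size from the only earlier step, a number 41.4 percentage points lower from compound 1 to compound 2 (beyond the scatter), which exchanged 4-hydroxyphenyl for 2-chlorophenyl at the saturated ring carbon. No measurement shown speaks to why the methyl leaves the read-out within the scatter.

The compounds shown leave open whether an amine, a carboxylic acid or a longer chain such as butyl, entering at this same place on the aromatic ring, would shift the read-out beyond the scatter. They also leave open whether the same exchange of phenyl for 4-methylphenyl would read alike in compounds carrying the carbonyl of compound 1 and compound 2 instead of the thiocarbonyl of compound 3 and compound 4.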